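This account rests on a few compounds, and the source may have more. Where it says the series, first, only, none or still open, it means among the compounds named here.

Three compounds from this series have been run in a functional assay on HT-29 cells (Homo sapiens) for inhibition, read by MTT assay, with a stated time of 72 h (on this read-out higher numbers stand for weaker inhibition and lower numbers for stronger inhibition), so far, and a fourth awaits measurement.

Compound 3 `COc1cc(/C=C/C(=O)/C=C(/C=C/c2ccc(O)c(OC)c2)NCC(C)C)ccc1O` carries an isobutyl group on its amine nitrogen and two free phenol groups. In this assay compound 3 gives 24500 nM. Compound 1 `CCC(C)NC(=C\C(=O)/C=C/c1ccc(O)c(OC)c1)/C=C/c1ccc(O)c(OC)c1` shares the core of compound 3 and differs from it in one place: sec-butyl in place of isobutyl on an amine nitrogen. For compound 1 the read-out in this assay is a limit of the assay, > 25000 nM, not a number. The step of an at least 1.0-fold higher number from compound 3 to compound 1 (0.00 log units; that floor lies within the scatter) is therefore only a floor, and one that lies within the scatter of the assay.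

Compound 2 `COc1cc(/C=C/C(=O)/C=C(/C=C/c2ccc(OC(C)=O)c(OC)c2)NCC(C)C)ccc1OC(C)=O` has acetylated phenols in place of the free ones; how its core differs from the core of compound 3 is not broken down here. In this assay the read-out for compound 2 is again a limit of the assay, > 25000 nM. Compound 4 `CCC(C)NC(=C\C(=O)/C=C/c1ccc(OC(C)=O)c(OC)c1)/C=C/c1ccc(OC(C)=O)c(OC)c1` is built from compound 2 by the same change that turns compound 3 into compound 1, namely (sec-butyl in place of isobutyl on an amine nitrogen).

The earlier step from compound 3 to compound 1 reached only the floor given by the limit of > 25000 nM in this assay, at which 2 of the 3 values shown sit, so no real size can be read from it. Since compound 2 already sits at the limit of > 25000 nM in this assay, at which 2 of the 3 values shown sit, the estimate for compound 4 is a step that the limit leaves unreadable from compound 2 to compound 4, expected to remain at that limit. Compound 4 is expected to give about 30000 nM, with a range from 20000 nM to 60000 nM.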

Compound 4, half-maximal inhibitory concentration: > 25000 nM
Compound 4 ended at the assay's limit; the forecaster's own chance of this, stated with the estimate: 85%; the middle value is on the limit's open side.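

Compound 2 and compound 4 both read as a limit of the assay and not as a number, so no step can be read between them for sec-butyl in place of isobutyl: the limit of > 25000 nM in this assay, at which 3 of the 4 values shown sit.

The compounds shown leave open how isobutyl and sec-butyl on the amine nitrogen compare in this assay, since compound 1, compound 2 and compound 4 give no number there.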